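Swapping the aryl group on the piperazine of a thione series

The source may hold more compounds than are shown below. What is called first, only, known or untested is meant among the compounds shown, and "the series" means these compounds.

Measured so far:
compound 1, `S=c1oc(-c2ccc3c(c2)OCCO3)nn1CN1CCN(C(c2ccccc2)c2ccccc2)CC1`: 21600 nM
compound 2, `COc1ccccc1N1CCN(Cn2nc(-c3ccc4c(c3)OCCO4)oc2=S)CC1`: 16900 nM
compound 3, `Fc1ccc(N2CCN(Cn3nc(-c4ccc5c(c4)OCCO5)oc3=S)CC2)cc1`: > 50000 nM

All three compounds share one core and differ only in the group carried by the ring nitrogen of the piperazine. In a functional assay on SW 1116 cells (Homo sapiens) for antiproliferative activity, read by MTT assay, with a stated time of 48 h (a higher number here means a weaker inhibitor, a lower number a stronger inhibitor), compound 2 gives 16900 nM. In this assay compound 1 gives 21600 nM, which sits within the scatter of the value for compound 2, so the two cannot be told apart. For compound 3 this assay reports only a limit, > 50000 nM, and not a number.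

For the measured compounds named here, the one step that can be read is an at least 2.9-fold higher number from compound 2 to compound 3 (0.47 log units; beyond the scatter). Exchanging the aryl group on that nitrogen therefore weakened the inhibitor, though only a lower bound on the size is known, because compound 3 sits at the limit of > 50000 nM in this assay, at which 1 of the 3 values shown sits.

Compound 4, `S=c1oc(-c2ccc3c(c2)OCCO3)nn1CN1CCN(c2ccccn2)CC1`, has not yet been measured. It differs from compound 2 in one place: pyridin-2-yl in place of 2-methoxyphenyl on an amine nitrogen in a ring. Going by the values given here, since the only measured exchange of this aryl group made the number higher, a step in the same direction is expected here, about a 2.1-fold higher number from compound 2 to compound 4 (0.32 log units; beyond the scatter). Compound 4 is therefore estimated at 35000 nM, between 15000 nM and 80000 nM.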

Compound 4, half-maximal inhibitory concentration: 9490 nM
For compound 4 the middle estimate is 3.7-fold (0.57 log units) above the measured one; measured number outside the range, below it.
By their numbers in this assay, from the lowest: compounds 4, 2 and 1 (each within the scatter of the next, the first and the last beyond it). At a limit, above all of these: compound 3.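

In this assay, the exchange gives a 1.8-fold lower number from compound 2 to compound 4 (0.25 log units; within the scatter), so pyridin-2-yl and 2-methoxyphenyl on this amine nitrogen cannot be told apart, and exchanging the aryl group here need not cost activity. The exchange of the other ring gives an at least 5.2-fold lower number from compound 3 to compound 4 (0.72 log units; beyond the scatter), which shows that this position does respond to the ring it carries and that pyridin-2-yl and 4-fluorophenyl are not interchangeable there. Only a lower bound on the size of that step is known, because compound 3 gives a limit and not a number: the limit of > 50000 nM in this assay, at which 1 of the 4 values shown sits.

The compounds shown do not separate the effect of the kind of substituent from that of its place on the ring, and 4-methoxyphenyl and 2-fluorophenyl would be the direct tests of that question. Going by these compounds, it also remains open whether the ring nitrogen of pyridin-2-yl matters at all, and a plain phenyl or a pyrimidin-2-yl group on the same piperazine nitrogen would help to settle this.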